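Working notes on the step to compound 3

A few compounds are considered here, and "the series" means these few. Any claim that something is new, unique, unknown or untested is made for them only; others in the source may bear on it.

Measured so far in a functional assay on Shh Light II cells (Mus musculus) for inhibition, read by a luciferase reporter; a lower number here means a stronger inhibitor, a higher number a weaker inhibitor:
- compound 1 `N#Cc1ccccc1NC(=O)N1CCC(c2nc(-c3ccc4ccccc4n3)no2)CC1` at 190 nM
- compound 2 `CC(=O)N1CCC(NC(=O)N2CCC(c3nc(-c4ccc5ccccc5n4)no3)CC2)CC1` at 500 nM

Compound 2 holds the higher of the two numbers, which makes it the weaker inhibitor of this pair. The next compound, compound 3 `O=C(Nc1ccccc1C(F)(F)F)N1CCC(c2nc(-c3ccc4ccccc4n3)no2)CC1`, carries 2-(trifluoromethyl)phenyl in place of 1-acetylpiperidin-4-yl on an amide-type nitrogen and is otherwise unchanged.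

For the measured compounds named here, the only measured step that bears on this is a 2.6-fold higher number from compound 1 to compound 2 (0.42 log units; beyond the scatter) with 1-acetylpiperidin-4-yl in place of 2-cyanophenyl on the same nitrogen. Compound 1 (190 nM) also has a substituted phenyl at that place, so a step of similar modest size toward a lower number is expected in this assay. Going by the values given here, no measurement yet compares 2-(trifluoromethyl)phenyl with 2-cyanophenyl, so the range stays wide. The estimated change is a 2.9-fold lower number from compound 2 to compound 3 (0.47 log units; beyond the scatter) on this reasoning. The value for compound 3 is expected at 170 nM (range 60 nM to 480 nM).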

Compound 3, half-maximal inhibitory concentration: 700 nM
The estimate for compound 3 lay 4.1-fold (0.61 log units) below the measured number; measured number outside the range, above it.
By their numbers in this assay, from the lowest: compound 1; then compounds 2 and 3 (each within the scatter of the next).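

In this assay, the kind of ring on the amide-type nitrogen does not by itself set the number: the reading is a 1.4-fold higher number from compound 2 to compound 3 (0.15 log units; within the scatter) and leaves 2-(trifluoromethyl)phenyl and 1-acetylpiperidin-4-yl not separated here, although one is a six-membered aromatic ring of carbon only and the other a six-membered non-aromatic ring with 1 hetero atom. The group on the aromatic ring does make a difference, since trifluoromethyl in place of cyano on an aromatic carbon gives a 3.7-fold higher number from compound 1 to compound 3 (0.57 log units; beyond the scatter) and compound 1 stays the lowest of the three, with its steps to both others beyond the scatter. For the compounds shown here, nothing measured so far explains why the cyano and trifluoromethyl compounds differ.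

The compounds shown leave open whether the lower number of compound 1 belongs to the cyano group specifically, or whether a phenyl ring with no substituent, or one carrying a chlorine atom or a methoxy group in place of the cyano, would match it. They also leave open how the piperidine side would read with a free amine in place of the acetyl group or with a carboxylic acid attached to that ring.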